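The compounds below may be only part of what the source reports. "The series", "measured", "known", "first", "only" and "open" are said of these compounds alone.

The measured compounds and their values:

compound 1, `O=C(Nc1cccc(Oc2ccccn2)c1)C1CCCN(C(=O)c2cc(C(F)(F)F)cc(C(F)(F)F)c2)C1` — compound 1 gives 0%
compound 2, `CSc1cccc(NC(=O)C2CCCN(C(=O)c3cc(C(F)(F)F)cc(C(F)(F)F)c3)C2)c1` — compound 2 gives 0%
compound 3, `CC(=O)c1cccc(NC(=O)C2CCCN(C(=O)c3cc(C(F)(F)F)cc(C(F)(F)F)c3)C2)c1` — compound 3 gives 0%

All three share one core and differ only in the group carried on the aromatic carbon of the aniline ring. In an ADME assay on PC-3 cells (Homo sapiens) for cytotoxicity, read by WST assay, tested at 100 uM (a lower number here means less inhibition, a higher number more inhibition at the concentration tested (going by the name of the read-out)), compound 3 stands level with compounds 1 and 2; its nearest neighbour is compound 1 and its furthest is compound 2, and neither gap goes beyond the scatter. The three pairwise steps confirm this: no change at the digits printed from compound 1 to compound 2 (within the scatter), no change at the digits printed from compound 1 to compound 3 (within the scatter) and no change at the digits printed from compound 2 to compound 3 (within the scatter). Replacing (pyridin-2-yl)oxy by methylsulfanyl or by acetyl, or methylsulfanyl by acetyl, left the read-out where it was.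

Compound 4, `C=CCOc1cccc(NC(=O)C2CCCN(C(=O)c3cc(C(F)(F)F)cc(C(F)(F)F)c3)C2)c1`, is the next member of the set. Its change relative to compound 3 is allyloxy in place of acetyl on an aromatic carbon.

Every step measured so far swapped the substituent on this same aromatic carbon and produced no change beyond the scatter. The step to compound 4 is of the same kind, so no movement beyond the scatter is expected in this assay; the expected step is no change at the digits printed from compound 3 to compound 4 (within the scatter). Compound 4 is therefore estimated at 0%, with a range from -5% to 12%.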

Compound 4, a percentage reported as inhibition, at one concentration (the size of the read-out at that concentration, not a potency): 0%
For compound 4 middle estimate and measured number coincide at the digits printed, and the stated range covers the measured number.
By their numbers in this assay, from the lowest: compounds 1, 2, 3 and 4 (each within the scatter of the next).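

In this assay, the position now carries an allyloxy group, and the swap from acetyl gives no change at the digits printed from compound 3 to compound 4 (within the scatter), while the swap from methylsulfanyl gives no change at the digits printed from compound 2 to compound 4 (within the scatter). Within the data shown here, the new comparison is with compound 1, the only earlier compound with an oxygen on this aromatic carbon: exchanging pyridin-2-yl for allyl on that oxygen, an open chain for an aromatic ring, gives no change at the digits printed from compound 1 to compound 4 (within the scatter), so this change to the group on the oxygen leaves the read-out as it was. No measurement shown here offers an explanation for this sameness.

All four compounds share a single value, so the series does not show whether any substituent at this position can shift the read-out in this assay at the concentration tested. On these data alone, it remains open whether an amine or a carboxylic acid on this aromatic carbon, or a change to the trifluoromethyl groups elsewhere on the shared core, would give a different value.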